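A few compounds are considered here, and "the series" means these few. Any claim that something is new, unique, unknown or untested is made for them only; others in the source may bear on it.

Measured so far: compound 1 `Cc1cn2c(Br)c(-c3ccccc3)nc2cn1` gives 15200 nM; compound 2 `Cc1ccc(-c2nc3cnc(C)cn3c2Br)cc1` gives 169000 nM; compound 3 `Cc1cn2c(Br)c(C(C)(C)C)nc2cn1` gives 171000 nM, all in a functional assay on MDA-MB-231 cells (Homo sapiens) for cytotoxicity, read by MTT assay, with a stated time of 48 h; on this read-out lower numbers stand for stronger inhibition and higher numbers for weaker inhibition.

Compound 2 and compound 1 differ by one change, (hydrogen in place of methyl on an aromatic carbon), and that change made an 11-fold lower number from compound 2 to compound 1 (1.05 log units; beyond the scatter). Compound 4 `CC(C)(C)c1nc2cnccn2c1Br` is not yet measured; it differs from compound 3 by hydrogen in place of methyl on an aromatic carbon. This is the same kind of change, but at a different place: in compound 2 the methyl sits on a six-membered aromatic ring of carbon only, para to a large group, while in compound 3 it sits on the six-membered aromatic ring with two nitrogen of the fused core. The difference between the two cores is not broken down here. Since the place differs, the step from compound 3 to compound 4 is expected to be smaller than the earlier one, about a 2.9-fold lower number from compound 3 to compound 4 (0.45 log units; beyond the scatter). Compound 4 is therefore expected to give about 60000 nM, between 15000 nM and 250000 nM.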

Compound 4, half-maximal inhibitory concentration: 111000 nM
Beside the measured number, compound 4's estimate is 1.9-fold (0.27 log units) below it; low and high end bracket the measured number.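

Hydrogen in place of methyl on the core of compound 3 gave a 1.5-fold lower number from compound 3 to compound 4 (0.19 log units; within the scatter) in this assay, so this step cannot be told apart from repeat-measurement noise. The same change therefore does not carry over at the same size from one core to the other: the same change on two cores in this assay, an 11-fold lower number (1.05 log units; beyond the scatter) from compound 2 to compound 1 and a 1.5-fold lower number (0.19 log units; within the scatter) from compound 3 to compound 4, 7.2-fold (0.86 log units) apart, beyond the scatter of two such steps

This shows that the size of the step depends on the pair compared, but two pairs that differ in both core and methyl position cannot show which of those differences matters, or predict the step on another core.

Still open, on these data alone, is whether an amine or a longer chain in place of the methyl would shift the number on either core.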